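A few compounds are considered here, and "the series" means these few. Any claim that something is new, unique, unknown or untested is made for them only; others in the source may bear on it.

Compound 1, `O=C(O)/C=C/c1ccc(Cn2cccn2)cc1OCCc1ccc2ccccc2c1`, is the reference point here: in an assay on CHO cells for displacement of a labelled ligand from prostaglandin E2 receptor EP4 subtype (Mus musculus), read by scintillation counting (a lower number here means a stronger inhibitor, a higher number a weaker inhibitor), compound 1 gives 670 nM. Compound 2, `Cc1ccc(/C=C/C(=O)O)c(OCCC2(C)CCc3c(C)c(O)c(C)c(C)c3O2)c1`, carries a different side chain and a methyl on the core; in this assay compound 2 gives 2200 nM, the higher of the two numbers, and its gap to compound 1 lies beyond the usual scatter of repeated measurements. Compound 3, `COc1ccc(/C=C/C(=O)O)c(OCCC2(C)CCc3c(C)c(O)c(C)c(C)c3O2)c1`, is the next compound and has not yet been measured. It differs from compound 2 by methoxy in place of methyl on an aromatic carbon. Within the data shown here, no pair of measured compounds that differ by this kind of exchange is available, so the size of the step rests on judgement alone. The exchange is expected to leave the number close to that of compound 2, with a 1.2-fold lower number from compound 2 to compound 3 (0.09 log units; within the scatter) anticipated to fall within the scatter or only slightly beyond it. Compound 3 is therefore estimated at 1800 nM in this assay, within a range from 700 nM to 4500 nM.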

Compound 3, inhibition constant: 920 nM
Estimate against measurement, compound 3: 2.0-fold (0.29 log units) above, within the range that was stated.
By their numbers in this assay, from the lowest: compounds 1 and 3 (each within the scatter of the next); then compound 2.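

On the aromatic carbon para to a 2-carboxyethenyl group, methoxy in place of methyl does not leave this assay unchanged: the exchange gives a 2.4-fold lower number from compound 2 to compound 3 (0.38 log units; beyond the scatter). Among these compounds, this single-place pair isolates that position for the first time in the account, whereas compound 1 differs from compound 2 in more than one place and could not show what this carbon contributes alone. No measurement shown here accounts for the step.

The compounds shown leave open how a hydroxyl, an ethoxy or a chlorine would read on this same aromatic carbon. They also leave open whether a methoxy there would give a comparable step with the side chain of compound 1, since one pair supports no general pattern for this exchange.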